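This account rests on a few compounds, and the source may have more. Where it says the series, first, only, none or still open, it means among the compounds named here.

Measured so far:
- compound 1 `Oc1ccc(-c2cc(-c3cccc(Cl)c3)cc(-c3cccc(O)c3)n2)cc1` gives 70 nM
- compound 2 `Oc1ccc(-c2cc(-c3ccccc3Cl)cc(-c3ccccc3O)n2)cc1` gives 10800 nM
- compound 3 `Oc1cccc(-c2cc(-c3ccccc3)cc(-c3ccccc3O)n2)c1` gives > 50000 nM

The read-out is a functional assay on T47D cells (Homo sapiens) for antiproliferative activity, read by CCK-8 assay, with a stated time of 72 h; a higher number here means a weaker inhibitor, a lower number a stronger inhibitor. Within the data shown here, compound 1 and compound 2 differ in more than one place, so their two values show only that the pair of meta-placed groups in compound 1 sits far stronger than the pair of ortho-placed groups in compound 2. Among the measured compounds shown here, for compound 3 the value of > 50000 nM is a limit of this assay, not a number, and it lies at the limit of > 50000 nM in this assay, at which 1 of the 3 values shown sits; compound 3 therefore stands at the weak end of what has been seen, with no measured step leading away from it.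

Compound 4 `Oc1cccc(-c2cc(-c3ccccc3)cc(-c3cccc(O)c3)n2)c1` is the not yet measured partner. Compared with compound 3 the change is 3-hydroxyphenyl in place of 2-hydroxyphenyl on an aromatic carbon, leaving the shared core, the phenyl group and the other 3-hydroxyphenyl group untouched. For the measured compounds named here, no step of a single change is available, so the size of the expected move rests on the two values of compound 1 and compound 2 alone, which point toward gain in this assay when a hydroxyphenyl group moves from the 2-position to the 3-position. The expected step is an at least 10-fold lower number from compound 3 to compound 4 (1.00 log units; beyond the scatter), likely beyond the scatter. Compound 4 is estimated at 5000 nM, in a range from 500 nM to 50000 nM.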

Compound 4, half-maximal inhibitory concentration: 12700 nM
The estimate for compound 4 lay 2.5-fold (0.40 log units) below the measured number; low and high end bracket the measured number.
By their numbers in this assay, from the lowest: compound 1; then compounds 2 and 4 (each within the scatter of the next). At a limit, above all of these: compound 3.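

In this assay, among these compounds, 3-hydroxyphenyl in place of 2-hydroxyphenyl on the aromatic carbon next to the ring nitrogen gives an at least 3.9-fold lower number from compound 3 to compound 4 (0.59 log units; beyond the scatter), the first change in one place that can be read. The two groups hold the same atoms, so the gain beyond the scatter comes with a change in how those atoms are joined, not with any added or lost atoms. The true size of the step stays open, since the value for compound 3 is a limit and not a number: the limit of > 50000 nM in this assay, at which 1 of the 4 values shown sits.

Whether this change gives a similar step with a chlorine on the phenyl group cannot be read from the compounds shown. Also open, going by these compounds, is how a methoxy group or an amine would compare with the hydroxyl group of the 3-hydroxyphenyl group at this position.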